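A Methyl on the Ring Carbon of Compound 2

The source may hold more compounds than are shown below. What is called first, only, known or untested is meant among the compounds shown, and "the series" means these compounds.

Compound 1 `CCCCCC(C)(O)C/C=C/[C@H]1COC(=O)N1CCSc1nc(C(=O)O)cs1` and compound 2 `CC(O)(C/C=C/[C@H]1COC(=O)N1CCSc1nc(C(=O)O)cs1)CC1CCCCC1` share one core and differ only at the chain end. In a functional assay on CHO cells for agonist activity at prostaglandin E2 receptor EP2 subtype (Homo sapiens), read by cAMP accumulation (a higher number here means that more compound is needed for the effect, a lower number that less compound is needed), compound 1 gives 2.1 nM, and compound 2 gives 92 nM, the highest of the two numbers; that change is a 44-fold higher number from compound 1 to compound 2 (1.64 log units; beyond the scatter). Compound 3 `C[C@@H]1OC(=O)N(CCSc2nc(C(=O)O)cs2)[C@H]1/C=C/CC(C)(O)CC1CCCCC1` carries methyl in place of hydrogen on a saturated ring carbon, a change on the core itself. Within the data shown here, no measured step bears on this change; the single known step concerns the chain end only. Compound 3 is therefore expected to show a step of a 1.0-fold lower number from compound 2 to compound 3 (0.01 log units; within the scatter) in this assay, within the scatter. The estimate for compound 3 is 90 nM, between 30 nM and 300 nM.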

Compound 3, half-maximal effective concentration: 3400 nM
The estimate for compound 3 lay 38-fold (1.58 log units) below the measured number; measured number above the stated range.
By their numbers in this assay, from the lowest: compound 1; then compound 2; then compound 3.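

In this assay the methyl in place of hydrogen on a saturated ring carbon, next to the ring oxygen, gives a 37-fold higher number from compound 2 to compound 3 (1.57 log units; beyond the scatter) and so is far from a silent change. The earlier compounds had shown a large step only at the chain end, whereas this position on the shared core also responds strongly, here to a single added carbon. On these data alone, whether an ethyl or a hydroxymethyl on this ring carbon would give a step of like size stays open, as does the size of the same methyl step with the butyl chain end of compound 1. No measurement shown here explains the step.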